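A few compounds are considered here, and "the series" means these few. Any claim that something is new, unique, unknown or untested is made for them only; others in the source may bear on it.

Series notes. Compound 1 `CCCCc1cccc(=O)n1Cc1ccc(-c2ccccc2-c2nn[nH]n2)cc1` gives 4 nM in a functional assay (aorta) for antagonist activity, with Oryctolagus cuniculus as the target (on this read-out higher numbers stand for weaker inhibition and lower numbers for stronger inhibition), the second highest of the three numbers; compound 3 `CCCCc1ccc(CN(C)S(=O)(=O)c2ccc(C)cc2)c(=O)n1Cc1ccc(-c2ccccc2-c2nn[nH]n2)cc1` gives 8 nM, within the scatter of compound 1, while compound 2 `CCCCc1ccc(CN(C)S(C)(=O)=O)c(=O)n1Cc1ccc(-c2ccccc2-c2nn[nH]n2)cc1` gives 0.2 nM, beyond it. Two steps are known: a 20-fold lower number from compound 1 to compound 2 (1.30 log units; beyond the scatter) and a 40-fold higher number from compound 2 to compound 3 (1.60 log units; beyond the scatter). Compound 4 `CCCCc1ccc(CNCc2ccccc2)c(=O)n1Cc1ccc(-c2ccccc2-c2nn[nH]n2)cc1` differs from compound 1 by (benzylamino)methyl in place of hydrogen on an aromatic carbon. Both measured steps bear on it: substitution at this carbon brought a large gain in compound 2, whereas bringing in an aromatic ring in compound 3 undid it. Compound 4 carries an aromatic ring but no sulfonyl, so a modest step is expected, a 1.3-fold lower number from compound 1 to compound 4 (0.12 log units; within the scatter), with wide uncertainty. The estimate for compound 4 is 3 nM (range 0.5 nM to 15 nM).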

Compound 4, half-maximal inhibitory concentration: 1 nM
For compound 4 the middle estimate is 3.0-fold (0.48 log units) above the measured one, and the stated range covers the measured number.
By their numbers in this assay, from the lowest: compound 2; then compound 4; then compounds 1 and 3 (each within the scatter of the next).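

In this assay, (benzylamino)methyl on this aromatic carbon still brings a gain (a 4.0-fold lower number from compound 1 to compound 4 (0.60 log units; beyond the scatter)), so a gain at this position does not depend on a sulfonyl. An aromatic ring in the substituent does not by itself cancel the gain, yet benzylamino stands between the two sulfonamides: an 8.0-fold lower number from compound 3 to compound 4 (0.90 log units; beyond the scatter) and a 5.0-fold higher number from compound 2 to compound 4 (0.70 log units; beyond the scatter). No measurement at hand accounts for these steps. 

Open, going by these compounds, is whether a smaller aminomethyl or a dimethylaminomethyl on this carbon would match the methylsulfonyl compound. On these data alone, a carboxylic acid here is equally open.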